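Compound 4 and the Diethylphenyl Change on the Aromatic Nitrogen

The source may report more compounds than this note shows. Statements on the series, on what has been measured and on what is new or still open speak of the compounds shown alone.

Among the measured compounds shown here, compound 3 `Cc1ccc(C)c(-n2nncc2CN2C(=O)C3(C(C#N)=C(N)Oc4c(N)cc5nc6ccccc6nc5c43)c3ccccc32)c1` is one of three compounds measured in an ADME assay on L02 cells (Homo sapiens) for antiproliferative activity, read by MTT assay, with a stated time of 48 h; a higher number here means a weaker inhibitor, a lower number a stronger inhibitor. In this assay compound 3 gives only the limit > 50000 nM. Compound 1 `N#CC1=C(N)Oc2c(N)cc3nc4ccccc4nc3c2C12C(=O)N(Cc1cnnn1-c1ccc(Cl)cc1)c1ccccc12` also gives only the limit > 50000 nM in this assay. Compound 2 `N#CC1=C(N)Oc2c(N)cc3nc4ccccc4nc3c2C12C(=O)N(Cc1cnnn1-c1cccc(C(F)(F)F)c1)c1ccccc12` gives 38100 nM in this assay. The step of an at least 1.3-fold higher number from compound 2 to compound 3 (0.11 log units; that floor lies within the scatter) and the step of an at least 1.3-fold lower number from compound 1 to compound 2 (0.11 log units; that floor lies within the scatter) are floors lying within the scatter, and the step that the two limits leave unreadable from compound 1 to compound 3 cannot be read at all; the limit of > 50000 nM in this assay, at which 2 of the 3 values shown sit, covers two of the three values. Compound 4 `CCc1cccc(CC)c1-n1nncc1CN1C(=O)C2(C(C#N)=C(N)Oc3c(N)cc4nc5ccccc5nc4c32)c2ccccc21` differs from compound 3 by 2,6-diethylphenyl in place of 2,5-dimethylphenyl on an aromatic nitrogen. For the measured compounds named here, no measured step exchanges the group on this aromatic nitrogen in the same way, and the swaps among 4-chlorophenyl, 3-(trifluoromethyl)phenyl and 2,5-dimethylphenyl all left the numbers at or close to the limit, so a step that the limit leaves unreadable from compound 3 to compound 4 is expected, none beyond the scatter. Compound 4 is therefore estimated at 60000 nM, between 30000 nM and 150000 nM, and is more likely than not to be reported again only as a limit.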

Compound 4, half-maximal inhibitory concentration: > 50000 nM
Compound 4: no number, only a limit; the forecaster's own chance of this, stated with the estimate: 75%; the middle value is on the limit's open side.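

The 2,6-diethylphenyl group, with 10 heavy atoms against the 8 of 2,5-dimethylphenyl, shows that a larger carbon-only aryl group on this aromatic nitrogen also leaves the read-out at the limit in this assay. Compound 4 gives > 50000 nM, which is a limit of the assay and not a number. The one readable step is an at least 1.3-fold higher number from compound 2 to compound 4 (0.11 log units; that floor lies within the scatter), while the steps to compound 4 from compound 1 and compound 3 cannot be read, with limits at both ends: the limit of > 50000 nM in this assay, at which 3 of the 4 values shown sit.

The compounds shown leave open whether any group on this nitrogen can bring the value clearly below the limit, for instance a phenyl ring carrying an amine or a carboxylic acid. They also leave open what a straight alkyl chain in place of the aryl ring would give.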